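A few compounds are considered here, and "the series" means these few. Any claim that something is new, unique, unknown or untested is made for them only; others in the source may bear on it.

Measured so far:
Compound 1, `COc1ccc2c(=O)c(/C=C/C(=O)NCc3cccc(F)c3)coc2c1`, gives > 200000 nM in a functional assay on L02 cells (Homo sapiens) for inhibition, read by MTT assay, with a stated time of 48 h; a higher number here means a weaker inhibitor, a lower number a stronger inhibitor; this value is a limit of the assay, not a number.
Compound 2, `COc1ccc(CNC(=O)/C=C/c2coc3cc(OC)ccc3c2=O)cc1`, gives > 200000 nM in this assay; this too is a limit.
Compound 3, `COc1ccc(CNC(=O)/C=C/c2coc3cc(O)ccc3c2=O)cc1`, gives > 200000 nM in this assay; again a limit.

Compound 2 therefore stands at the limit, where every value shown sits (the limit of > 200000 nM in this assay, at which 3 of the 3 values shown sit). The steps a step that the two limits leave unreadable from compound 1 to compound 2 and a step that the two limits leave unreadable from compound 2 to compound 3 cannot be sized, both ends sitting at that limit. Compound 4, `COc1ccc2c(=O)c(/C=C/C(=O)NCc3ccc(C)cc3)coc2c1`, differs from compound 2 by methyl in place of methoxy on an aromatic carbon. Neither measured step bears readably on this change, so in this assay no step beyond the scatter is expected in either direction. Compound 4 is expected to stay at the limit, estimated at 200000 nM with range 100000 nM to 400000 nM. The expected step is a number no higher from compound 2 to compound 4 (the limit leaves the size open).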

Compound 4, half-maximal inhibitory concentration: > 200000 nM
Compound 4: no number, only a limit; the forecaster's own chance of this, stated with the estimate: 85%; the middle value lies on the limit itself.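

Compound 4 gives only a limit in this assay, as do compound 1 and compound 2, so neither of its steps to them can be read: the limit of > 200000 nM in this assay, at which 4 of the 4 values shown sit. Which change, if any, would bring a measurable value stays open.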